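Swapping the Aryl Group Leaves Acid Dissociation Nearly Unchanged

The source may report more compounds than this note shows. Statements on the series, on what has been measured and on what is new or still open speak of the compounds shown alone.

Of the two measured numbers in a physicochemical assay for acid dissociation, compound 2 `COc1ccc(F)cc1CNCCCNc1ccnc2cc(Oc3cccc(N(C)C)c3)ccc12` gives 9.28, within the scatter of compound 1 `COc1ccc(F)cc1CNCCCNc1ccnc2cc(-c3ccc(F)cc3)ccc12` at 9.47. Compound 3 `COc1ccc(-c2ccc3c(NCCCNCc4cc(F)ccc4OC)ccnc3c2)cc1` differs from compound 2 by 4-methoxyphenyl in place of 3-(dimethylamino)phenoxy on an aromatic carbon. Going by the values given here, the single step that bears on this change, a number 0.19 log units lower from compound 1 to compound 2 (within the scatter), also exchanged a group on this same aromatic carbon and stayed within the scatter, so no step beyond the scatter is expected in this assay for compound 3. Compound 3 is therefore estimated at 9.4, between 9.1 and 9.7. The expected step from compound 2 to compound 3 is a number 0.12 log units higher from compound 2 to compound 3 (within the scatter).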

Compound 3, acid dissociation constant: 9.47
For compound 3 the middle estimate is 0.07 log units below the measured one; low and high end bracket the measured number.
By their numbers in this assay, from the lowest: compounds 2, 1 and 3 (each within the scatter of the next).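

In this assay, two further exchanges at this aromatic carbon both stay within the scatter: a number 0.19 log units higher from compound 2 to compound 3 (within the scatter) for the larger swap of groups, and no change at the digits printed from compound 1 to compound 3 (within the scatter) for methoxy in place of fluoro. This position has now carried three different groups, 4-fluorophenyl, 3-(dimethylamino)phenoxy and 4-methoxyphenyl, without any step beyond the scatter. Nothing available here accounts for this. Going by these compounds, whether a carboxylic acid or a primary amine on this same carbon would also stay within the scatter remains open.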